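Compound 2 to compound 3: half-life in mouse microsomes

A few compounds are considered here, and "the series" means these few. Any claim that something is new, unique, unknown or untested is made for them only; others in the source may bear on it.

Measured in an ADME assay (liver, Mus musculus) for metabolic stability, using microsomes; a higher number here means that the compound lasts longer, a lower number that the compound disappears faster:
- compound 1 `CCc1nc2cc(Cl)ccn2c1C(=O)NCc1ccc(N2CCCCC2)cc1`: 0.0383 h
- compound 2 `CCc1nc2cc(Cl)ccn2c1C(=O)NCc1ccc(N2CCC(Cl)CC2)cc1`: 0.0867 h

Compound 2 holds the higher of the two numbers in this assay, at 0.0867 h. The next change gives compound 3 `CCc1nc2cc(Cl)ccn2c1C(=O)NCc1ccc(N2CCN(C(C)C)CC2)cc1`, and the difference is 4-isopropylpiperazin-1-yl in place of 4-chloropiperidin-1-yl on an aromatic carbon. In words, 4-isopropylpiperazin-1-yl stands in place of 4-chloropiperidin-1-yl on an aromatic carbon, para to a large group.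

Among the compounds with values here, only one measured step bears on this, a 2.3-fold higher number from compound 1 to compound 2 (0.35 log units; beyond the scatter). It was modest and beyond the scatter, and it came with chloro in place of hydrogen on a saturated ring carbon. Compound 3 no longer carries that chloro, so the gain seen in that step is not expected to carry over in full. Within the data shown here, the data hold no measured example of a 4-isopropylpiperazin-1-yl group, so the link is loose. A downward step no larger than the measured one is expected, and it may stay within the scatter. The expected step is a 1.6-fold lower number from compound 2 to compound 3 (0.20 log units; within the scatter). For compound 3 the estimated half-life is 0.055 h, with an expected range of 0.025 h to 0.13 h.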

Compound 3, half-life: 0.148 h
For compound 3 the middle estimate is 2.7-fold (0.43 log units) below the measured one; measured number outside the range, above it.
By their numbers in this assay, from the lowest: compound 1; then compounds 2 and 3 (each within the scatter of the next).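

In this assay, the aromatic carbon para to a large group accepts 4-isopropylpiperazin-1-yl in place of 4-chloropiperidin-1-yl with no separation between the two compounds (a 1.7-fold higher number from compound 2 to compound 3 (0.23 log units; within the scatter)), so the chloro is not needed to reach the level of compound 2. Set against the plain piperidin-1-yl ring, the same group gives a step beyond the scatter (a 3.9-fold higher number from compound 1 to compound 3 (0.59 log units; beyond the scatter)), which means that two different substituted rings at this place, one with 1 hetero atom and one with 2, now both stand clear of compound 1 (a 2.3-fold higher number from compound 1 to compound 2 (0.35 log units; beyond the scatter)), and none of the three compounds goes against this. No measurement in hand accounts for the behaviour of either ring at this place.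

The compounds shown do not separate the contribution of the isopropyl group from that of the extra ring nitrogen, a question that a piperazine carrying a methyl group or no substituent at all would address. Also open, from the compounds shown here alone, is how a morpholine ring, or a piperidine carrying fluoro or hydroxy in place of the chloro, would compare at this same aromatic carbon.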